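Adding a second chloro to a 2-aminothiophene ketone series

The compounds below may be only part of what the source reports. "The series", "measured", "known", "first", "only" and "open" are said of these compounds alone.

Measured compounds:
- compound 1 `CC(C)(C)Cc1csc(N)c1C(=O)c1ccc(Cl)cc1` gives 1% in an assay on CHO cells for displacement of a labelled ligand from adenosine receptor A1 (Homo sapiens), read by scintillation counting, tested at 10 uM; on this read-out higher numbers stand for more inhibition at the one concentration tested (going by the name of the read-out) and lower numbers for less inhibition
- compound 2 `CC(C)(C)Cc1csc(N)c1C(=O)c1cccc(Cl)c1` gives 2% in this assay
- compound 3 `CC(C)(C)Cc1c(-c2ccccn2)sc(N)c1C(=O)c1ccc(Cl)cc1` gives 1% in this assay

All three numbers are low and close together. Compound 2 shows the largest of the three figures, but compound 1 and compound 3 both lie within the usual scatter of it, so nothing separates them. Going by the values given here, the one step between compounds differing in a single place is no change at the digits printed from compound 1 to compound 3 (within the scatter), which shows that a sizeable addition on the core left the read-out unchanged.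

Compound 4 `CC(C)(C)Cc1csc(N)c1C(=O)c1ccc(Cl)c(Cl)c1` is not yet measured. It arises from compound 2 by chloro in place of hydrogen on an aromatic carbon, placed on the six-membered aromatic ring of carbon only, para to the large group. Among the compounds with values here, no measured step addresses a change on that ring, so the only guide is the flat behaviour across compounds 1 to 3. The step is therefore expected to be a number 1 percentage points higher from compound 2 to compound 4 (within the scatter), none beyond the scatter, and compound 4 is expected to give about 3%, between -6% and 14%.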

Compound 4, a percentage reported as inhibition, at one concentration (the size of the read-out at that concentration, not a potency): 1%
Compound 4: the middle estimate sits 2 percentage points above what was measured; the measured number falls inside the stated range.
By their numbers in this assay, from the lowest: compounds 1, 3, 4 and 2 (each within the scatter of the next).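

Going by these compounds alone, the second chloro is the first change on the six-membered aromatic ring of carbon only that can be read as a step, and in this assay it gives no separation from either parent carrying a single chloro (a number 1 percentage points lower from compound 2 to compound 4 (within the scatter); no change at the digits printed from compound 1 to compound 4 (within the scatter)). The two routes to compound 4 agree, so a chloro ortho to a chloro group on this ring leaves the read-out as flat as the pyridin-2-yl addition on the core did. Nothing available accounts for this flat behaviour.

On these data alone, whether an amine or a carboxylic acid at this position would raise the read-out remains open. Within the data shown here, with all four compounds this close to nothing, any step that would lower inhibition could not be seen, so the series so far shows only that these changes bring no visible gain.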